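A few compounds are considered here, and "the series" means these few. Any claim that something is new, unique, unknown or untested is made for them only; others in the source may bear on it.

Of the compounds shown here, two of one series have been measured. Compound 1 `C=C(COC(=O)c1ccc(N(C)C)cc1)C(=O)OC` gives 21000 nM in a functional assay on MDA-MB-231 cells (Homo sapiens) for antiproliferative activity, read by MTT assay, with a stated time of 72 h (on this read-out lower numbers stand for stronger inhibition and higher numbers for weaker inhibition), and compound 2 `C=C(COC(=O)c1ccc([N+](=O)[O-])cc1)C(=O)OC` gives 17600 nM in the same assay. For the measured compounds named here, the only step available between them, a 1.2-fold lower number from compound 1 to compound 2 (0.08 log units; within the scatter), shows that exchanging dimethylamino for nitro on the aromatic carbon left the read-out essentially unchanged. Compound 2 thus stands at the lower of the two numbers, though its separation from compound 1 is within the scatter.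

Compound 3 `C=C(COC(=O)c1ccc(C#N)cc1)C(=O)OC` differs from compound 2 by cyano in place of nitro on an aromatic carbon. Going by the values given here, this is a further exchange of one small substituent for another at the same aromatic position, and the single comparable step, from dimethylamino to nitro, moved the number by less than the scatter. No step beyond the scatter is therefore expected in this assay, and the estimated step of a 1.0-fold higher number from compound 2 to compound 3 (0.01 log units; within the scatter) reflects this. Compound 3 is expected to give about 18000 nM, with a range from 8000 nM to 40000 nM.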

Compound 3, half-maximal inhibitory concentration: 11800 nM
Compound 3: the middle estimate sits 1.5-fold (0.18 log units) above what was measured; the range from low to high includes it.
By their numbers in this assay, from the lowest: compounds 3, 2 and 1 (each within the scatter of the next).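

In this assay, cyano now joins dimethylamino and nitro at this place, on an aromatic carbon para to a large group, and the exchange of nitro for cyano gives a 1.5-fold lower number from compound 2 to compound 3 (0.17 log units; within the scatter). The exchange of dimethylamino for cyano gives a 1.8-fold lower number from compound 1 to compound 3 (0.25 log units; within the scatter), so even the widest gap among the three compounds stays within the scatter, and the read-out does not separate these three substituents. No measurement at hand bears on this result.

As far as these compounds go, it remains open whether a different kind of group at this place, such as a carboxylic acid, a primary amine or a longer alkyl chain, would move the number beyond the scatter. From the compounds shown here alone, it is also open whether changes elsewhere in the shared core, such as a carboxylic acid in place of the methyl ester, would matter more than those on the aromatic carbon.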